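The compounds below may be only part of what the source reports. "The series", "measured", "known", "first", "only" and "open" are said of these compounds alone.

Measured compounds:
compound 1 `COc1ccc(-c2cc(/C=C/C(=O)c3ccc(N)cc3)[nH]n2)cc1`, in a functional assay on MDA-MB-468 cells (Homo sapiens) for cytotoxicity, read by sulforhodamine B assay, with a stated time of 48 h, tested at 10 uM (on this read-out lower numbers stand for a stronger effect and higher numbers for a weaker effect at the one concentration tested), gives -62%
compound 2 `COc1cc(-c2cc(/C=C/C(=O)c3ccc(N)cc3)[nH]n2)cc(OC)c1OC`, in this assay gives -58%
compound 3 `COc1ccc(C(=O)/C=C/c2cc(-c3cc(OC)c(OC)c(OC)c3)n[nH]2)cc1OC`, in this assay gives -87%

Compound 2 stands highest of the three numbers, but its nearest neighbour, compound 1, lies within the scatter of it, so the two cannot be ordered; only compound 3 lies clearly apart, with a number 29 percentage points lower from compound 2 to compound 3 (beyond the scatter). That step exchanged the group on the carbonyl carbon, a place the new compound does not touch. Compound 4 `COc1ccc(-c2cc(/C=C/C(=O)c3ccc(N)cc3)[nH]n2)cc1OC` differs from compound 2 by hydrogen in place of methoxy on an aromatic carbon. Within the data shown here, no measured step alters this ring alone, so the only guide is that compound 1 and compound 2, which carry a different number of methoxy groups on the same ring, give numbers within the scatter of each other. A change at this ring is therefore expected to produce no step beyond the scatter, which is the meaning of the expected a number 2 percentage points lower from compound 2 to compound 4 (within the scatter). Compound 4 is thus estimated at -60%, with a range from -75% to -45%.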

Compound 4, a percentage reported as activity, at one concentration (the size of the read-out at that concentration, not a potency): -65%
The estimate for compound 4 lay 5 percentage points above the measured number, and the stated range covers the measured number.
By their numbers in this assay, from the lowest: compound 3; then compounds 4, 1 and 2 (each within the scatter of the next).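

In this assay, removing a methoxy group from this six-membered aromatic ring gives a number 7 percentage points lower from compound 2 to compound 4 (within the scatter) and adding one gives a number 3 percentage points lower from compound 1 to compound 4 (within the scatter) in a single change. Among these compounds, compound 1 and compound 2 differ in more than one place, so these are the first single-place steps at this ring: with the 4-aminophenyl group on the carbonyl carbon, exchanging methoxy and hydrogen here leaves the read-out within the scatter. Nothing available explains why this exchange makes so little difference.

Going by these compounds, it remains open whether the ring behaves the same way when the carbonyl carbon carries the 3,4-dimethoxyphenyl group of compound 3. On these data alone, the outcome of placing a hydroxyl group, an amine or a longer chain such as ethoxy on this ring also remains open.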